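Oxime series: pyrazinyl to phenyl on the oxime carbon

The source may report more compounds than this note shows. Statements on the series, on what has been measured and on what is new or still open speak of the compounds shown alone.

Measured so far in an ADME assay on CHO cells (Cricetulus griseus) for cytotoxicity; a lower number here means a stronger inhibitor, a higher number a weaker inhibitor:
compound 1 `Cc1cnc(/C(=N\O)c2nc3ccccc3s2)s1` gives 29000 nM
compound 2 `O/N=C(\c1cnco1)c1nc2ccccc2s1` gives > 100000 nM
compound 3 `O/N=C(\c1cnccn1)c1nc2ccccc2s1` gives 11700 nM

The value of compound 2 is a limit of this assay, not a number (the limit of > 100000 nM in this assay, at which 1 of the 3 values shown sits). Of the two numbers in hand, compound 3 stands lowest; its nearest neighbour is compound 1, with a 2.5-fold lower number from compound 1 to compound 3 (0.39 log units; beyond the scatter) between them. The step of an at least 8.5-fold lower number from compound 2 to compound 3 (0.93 log units; beyond the scatter) runs in the same direction, and an at least 3.4-fold higher number from compound 1 to compound 2 (0.53 log units; beyond the scatter) completes the triangle. Each of these steps exchanges one heteroaromatic ring for another on the carbon with a double bond to nitrogen.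

Compound 4 `O/N=C(\c1ccccc1)c1nc2ccccc2s1` is the next member to be measured. It differs from compound 3 as follows: phenyl in place of pyrazin-2-yl on a carbon with a double bond to nitrogen. Within the data shown here, no measured step exchanges a heteroaromatic ring for a ring of carbon only, so the three steps above bear on it only loosely; they show that swaps at this position move the number by modest amounts, in both directions. A step of modest size is therefore expected for a 2.1-fold higher number from compound 3 to compound 4 (0.33 log units; beyond the scatter), most likely toward a higher number. Compound 4 is expected to give about 25000 nM in this assay, within 8000 nM to 80000 nM.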

Compound 4, half-maximal inhibitory concentration: > 100000 nM
Compound 4 was reported as a limit (the forecaster's own chance of this, stated with the estimate: 15%); at least 4.0-fold (0.60 log units) between middle value and limit.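

Among these compounds, the value of compound 4 in this assay is a limit, not a number, and it is the second such limit in the set: the limit of > 100000 nM in this assay, at which 2 of the 4 values shown sit. Phenyl in place of pyrazin-2-yl gives an at least 8.5-fold higher number from compound 3 to compound 4 (0.93 log units; beyond the scatter), the first exchange at this carbon of a heteroaromatic ring for a ring of carbon only, and an at least 3.4-fold higher number from compound 1 to compound 4 (0.53 log units; beyond the scatter) runs the same way. Hetero atoms in the ring do not by themselves give a low number, since compound 2 also sits at the limit, and the steps between compound 2 and compound 4 cannot be read.

From the compounds shown here alone, the true numbers of compound 2 and compound 4 stay open, so these two groups cannot be ordered. Also open, going by these compounds, is whether a phenyl carrying an amine or a carboxylic acid would bring the number back toward that of compound 3.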